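The compounds below may be only part of what the source reports. "The series", "measured", "known", "first", "only" and "open" are said of these compounds alone.

Compound 1 `O=C1C=COC(/C=C/c2ccc(C(F)(F)F)cc2)C1` and compound 3 `O=C1C=CCC(/C=C/c2ccc(C(F)(F)F)cc2)O1` are built from the same atoms joined differently; the difference between the two cores is not broken down here. In a functional assay on HT-29 cells (Homo sapiens) for inhibition, read by sulforhodamine B assay, with a stated time of 48 h (on this read-out lower numbers stand for stronger inhibition of growth and higher numbers for weaker inhibition of growth), compound 1 gives 33.3 uM and compound 3 gives 36.2 uM, two values that lie within the usual scatter of each other. Compound 2 `COc1ccc(/C=C/C2CC(=O)C=CO2)cc1` gives 204 uM in this assay. The change from compound 1 to compound 2 is methoxy in place of trifluoromethyl on an aromatic carbon, and it made a 6.1-fold higher number from compound 1 to compound 2 (0.79 log units; beyond the scatter). Compound 4 `COc1ccc(/C=C/C2CC=CC(=O)O2)cc1` is not yet measured; it differs from compound 3 by methoxy in place of trifluoromethyl on an aromatic carbon, the same change, occurring twice among these compounds with places that match word for word. Because compound 1 gives 33.3 uM close to compound 3 at 36.2 uM, the step is expected to repeat: a 5.5-fold higher number from compound 3 to compound 4 (0.74 log units; beyond the scatter), beside a 6.1-fold higher number from compound 1 to compound 2 (0.79 log units; beyond the scatter). Compound 4 is therefore expected to give about 200 uM in this assay, with a plausible range from 90 uM to 450 uM.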

Compound 4, concentration for growth inhibition (reported as GI): 33.7 uM
For compound 4 the middle estimate is 5.9-fold (0.77 log units) above the measured one; the whole stated range lies above it.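

Moving from trifluoromethyl to methoxy in this assay gave a 1.1-fold lower number from compound 3 to compound 4 (0.03 log units; within the scatter), so the step seen on the core of compound 1 did not carry over to the core of compound 3: the same change on two cores in this assay, a 6.1-fold higher number (0.79 log units; beyond the scatter) from compound 1 to compound 2 and a 1.1-fold lower number (0.03 log units; within the scatter) from compound 3 to compound 4, 6.6-fold (0.82 log units) apart, beyond the scatter of two such steps. In this series, then, the effect of this change on one core cannot be assumed to hold on the other. These two pairs do not show why the cores part ways, nor how the change would behave on any further core.

On these data alone, it remains open whether other groups at the same place on the aromatic ring, such as an amine, a carboxylic acid or a nitrile, would also give different steps on the two cores.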